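Phenylethynyl benzamides: amide substituent change from compound 1

The source may hold more compounds than are shown below. What is called first, only, known or untested is meant among the compounds shown, and "the series" means these compounds.

Measured compounds:
- compound 1 `O=C(NCc1ccsc1)c1ccc(C#Cc2ccccc2)cc1`: 1200 nM
- compound 2 `O=C(NCc1ccsc1)c1ccc(C#Cc2ccccc2)nc1`: 140 nM

In a functional assay on BHK cells for positive allosteric modulation of metabotropic glutamate receptor 5 (Homo sapiens), read by FLIPR and calcium flux (a higher number here means that more compound is needed for the effect, a lower number that less compound is needed), compound 1 gives 1200 nM, the higher of the two numbers recorded; compound 2 gives 140 nM, a gap beyond the scatter. Compound 3 `CC1CCN(C(=O)c2ccc(C#Cc3ccccc3)cc2)CC1` is not yet measured. It differs from compound 1 by 4-methylpiperidin-1-yl in place of ((thiophen-3-yl)methyl)amino on a carbonyl carbon. Among the measured compounds shown here, no measured pair shows this change, so its size is unknown. Compound 3 is expected to give a somewhat higher number, estimated at 2500 nM with a range from 600 nM to 10000 nM, an expected step of a 2.1-fold higher number from compound 1 to compound 3 (0.32 log units; beyond the scatter) that may still fall within the scatter.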

Compound 3, half-maximal effective concentration: 720 nM
Estimate against measurement, compound 3: 3.5-fold (0.54 log units) above; the range from low to high includes it.
By their numbers in this assay, from the lowest: compound 2; then compounds 3 and 1 (each within the scatter of the next).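

In this assay, a 1.7-fold lower number from compound 1 to compound 3 (0.22 log units; within the scatter) comes with 4-methylpiperidin-1-yl in place of ((thiophen-3-yl)methyl)amino on the carbonyl carbon. This position therefore accepts a non-aromatic ring and loss of the amide hydrogen with no change beyond the scatter. No supporting data bear on why this exchange leaves the number within the scatter.

Still open, on these data alone, is whether 4-methylpiperidin-1-yl would give a similar result on the core of compound 2. Also open, as far as these compounds go, is how a morpholine or an unsubstituted piperidine would read at this position.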